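A methoxyphenyl exchange on compound 3

The compounds below may be only part of what the source reports. "The series", "measured", "known", "first", "only" and "open" are said of these compounds alone.

In an ADME assay on Caco-2 cells (Homo sapiens) for permeability, read by LC-MS, in the apical to basolateral direction, with a stated time of 2 h, tested at 2 uM (on this read-out higher numbers stand for higher permeability and lower numbers for lower permeability), compound 1 `CC[C@@H](Nc1c(C#N)c(-c2ccc(-c3ccccc3F)cc2)nc2cnccc12)C(N)=O` gives 140 nm/s, compound 2 `CCOc1ccccc1-c1ccc(-c2nc3cncc(Cl)c3c(N[C@H](CC)C(N)=O)c2C#N)cc1` gives 17 nm/s, and compound 3 `CC[C@@H](Nc1c(C#N)c(-c2ccc(-c3cccc(C)c3F)cc2)nc2cnccc12)C(N)=O` gives 47 nm/s. Compound 3 thus holds the middle place of the three, with a gap beyond the usual scatter on either side.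

Compound 4 `CC[C@@H](Nc1c(C#N)c(-c2ccc(-c3ccc(OC)cc3)cc2)nc2cnccc12)C(N)=O` carries another outer group: 4-methoxyphenyl in place of 2-fluoro-3-methylphenyl on an aromatic carbon. For the measured compounds named here, one measured step bears on this change, a 3.0-fold lower number from compound 1 to compound 3 (0.47 log units; beyond the scatter), where a methyl took the place of a hydrogen on an aromatic carbon. That step is modest and covers only part of the exchange. Compound 2 differs from compound 4 in more than one place and offers no clean comparison. Going by the values given here, no measured step covers the whole group, so the direction remains uncertain. Compound 4 has no methyl on this group, as in compound 1, and the step of a 3.0-fold lower number from compound 1 to compound 3 (0.47 log units; beyond the scatter) therefore points to a slight rise at most. The estimated change is a 1.4-fold higher number from compound 3 to compound 4 (0.14 log units; within the scatter), and no step beyond the scatter is expected. For compound 4 the estimated value is 65 nm/s, with an expected range from 20 nm/s to 190 nm/s.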

Compound 4, apparent permeability: 114 nm/s
Beside the measured number, compound 4's estimate is 1.8-fold (0.24 log units) below it; the measured number falls inside the stated range.
By their numbers in this assay, from the lowest: compound 2; then compound 3; then compounds 4 and 1 (each within the scatter of the next).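

Putting 4-methoxyphenyl in place of 2-fluoro-3-methylphenyl on this aromatic carbon gives a 2.4-fold higher number from compound 3 to compound 4 (0.38 log units; beyond the scatter) in this assay and so takes the number back up to the level of compound 1. Against the 2-fluorophenyl group the same outer group gives a 1.2-fold lower number from compound 1 to compound 4 (0.09 log units; within the scatter), so compound 1 and compound 4 cannot be told apart here even though their outer rings carry different groups. Among the compounds on this unchlorinated core, only compound 3 with its added methyl stands apart, and nothing at hand explains why.

The compounds shown do not separate the effect of the methoxy oxygen from that of its place on the ring. As far as these compounds go, how an amine or a carboxylic acid on this outer ring would read remains open, as does whether 4-methoxyphenyl would give the same result on the chlorinated core of compound 2.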